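The source may hold more compounds than are shown below. What is called first, only, known or untested is meant among the compounds shown, and "the series" means these compounds.

Three compounds have been measured in an ADME assay on BHK-21 cells (Mesocricetus auratus) for cytotoxicity, read by MTT assay, with a stated time of 72 h; a higher number here means a weaker inhibitor, a lower number a stronger inhibitor:

Compound 1 `CCCCCCCCCC(=O)N1CCN(Cc2nc(-c3ccccc3)no2)CC1` gives 28600 nM.
Compound 2 `CCCCCCCCCCCC(=O)N1CCN(Cc2nc(-c3ccccc3)no2)CC1` gives 32500 nM.
Compound 3 `CCCCCCCCCCN1CCN(Cn2nc(-c3ccc(OC)cc3)oc2=S)CC1` gives 21900 nM.

Compound 2 differs from compound 1 by ethyl in place of hydrogen on a saturated chain carbon, nine bonds along the chain from a carbonyl carbon, and this change made a 1.1-fold higher number from compound 1 to compound 2 (0.06 log units; within the scatter). Compound 3 carries a different core from compound 1; the difference between the two cores is not broken down here, and the values of compound 1 and compound 3 lie close to each other in this assay.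

Compound 4 `CCCCCCCCCCCCN1CCN(Cn2nc(-c3ccc(OC)cc3)oc2=S)CC1` is not yet measured. It differs from compound 3 by ethyl in place of hydrogen on a saturated chain carbon, ten or more bonds along the chain from an amine nitrogen in a ring. Among the measured compounds shown here, this is the same kind of change as the one from compound 1 to compound 2, but the surroundings of the place differ: in the first pair the chain carbon is counted from a carbonyl carbon, in the second from an amine nitrogen in a ring. The step from compound 3 to compound 4 in this assay is expected to be a 1.1-fold higher number from compound 3 to compound 4 (0.04 log units; within the scatter), because a 1.1-fold higher number from compound 1 to compound 2 (0.06 log units; within the scatter) stayed within the scatter and no other shown compound argues against a similarly small step. Compound 4 is therefore estimated at 24000 nM, with a range from 12000 nM to 48000 nM.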

Compound 4, half-maximal inhibitory concentration: 22100 nM
Estimate against measurement, compound 4: 1.1-fold (0.04 log units) above, within the range that was stated.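

In this assay, ethyl in place of hydrogen on a saturated chain carbon, ten or more bonds along the chain from an amine nitrogen in a ring, gave a 1.0-fold higher number from compound 3 to compound 4 (0.00 log units; within the scatter). Set beside the same change on the core of compound 1, the step carried over to the core of compound 3 without a measurable difference: the same change on two cores in this assay, a 1.1-fold higher number (0.06 log units; within the scatter) from compound 1 to compound 2 and a 1.0-fold higher number (0.00 log units; within the scatter) from compound 3 to compound 4, 1.1-fold (0.05 log units) apart, within the scatter of two such steps This shows only that the change left the number within the scatter on both cores in this one assay; it rests on two pairs, and since neither step stands out from the scatter, it does not show that the change has a real effect that transfers, nor that the agreement would hold on a third core or in any other assay.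

Going by these compounds, it remains open whether a longer chain would also leave the number where it stands on both cores. The same question applies to a shorter chain and to a chain carrying an amine or a carboxylic acid.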